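Tert-butyl in place of fluorophenyl: cytotoxicity on Vero cells

This account rests on a few compounds, and the source may have more. Where it says the series, first, only, none or still open, it means among the compounds named here.

Compound 1 `O=C(O)c1cn(-c2ccc(F)cc2)c2nc(N3CCN(C(c4ccccc4)c4ccc(Cl)cc4)CC3)c([N+](=O)[O-])cc2c1=O`: in an ADME assay on Vero cells (Chlorocebus sabaeus) for cytotoxicity, read by MTT assay, with a stated time of 72 h (on this read-out higher numbers stand for weaker inhibition and lower numbers for stronger inhibition), compound 1 gives 102000 nM.
Compound 2 `CCN(CC)C(=O)C1CCCN(c2nc3c(cc2[N+](=O)[O-])c(=O)c(C(=O)O)cn3-c2ccc(F)cc2)C1`: in this assay compound 2 reaches only a limit, > 122000 nM.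
Compound 3 `CC(C)(C)n1cc(C(=O)O)c(=O)c2cc([N+](=O)[O-])c(N3CCN(C(c4ccccc4)c4ccc(Cl)cc4)CC3)nc21`: in this assay compound 3 also reaches only a limit, > 108000 nM.

All three measured compounds share a nitro-bearing bicyclic core with a carboxy group, and each shows weak cytotoxicity on these cells. Compound 1 and compound 3 differ in one place, (tert-butyl in place of 4-fluorophenyl on an aromatic nitrogen). The step is an at least 1.0-fold higher number from compound 1 to compound 3 (0.02 log units; that floor lies within the scatter), and since compound 3 stands at the limit of > 108000 nM in this assay, at which 1 of the 3 values shown sits, only a floor for the step is known.

Compound 2 carries a different amine side chain, and how its core differs from that of compound 1 is not broken down here. Compound 2 stands at the limit of > 122000 nM in this assay, at which 1 of the 3 values shown sits.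

Compound 4 `CCN(CC)C(=O)C1CCCN(c2nc3c(cc2[N+](=O)[O-])c(=O)c(C(=O)O)cn3C(C)(C)C)C1` has not yet been measured. It is related to compound 2 by the same change that turns compound 1 into compound 3, namely (tert-butyl in place of 4-fluorophenyl on an aromatic nitrogen). Because compound 2 already stands at the limit of > 122000 nM in this assay, at which 1 of the 3 values shown sits, and because the change from compound 1 to compound 3 gave an at least 1.0-fold higher number from compound 1 to compound 3 (0.02 log units; that floor lies within the scatter), a step that the limit leaves unreadable from compound 2 to compound 4 is expected, most likely ending again at a limit rather than a number. The value of compound 4 in this assay is estimated at 130000 nM, between 80000 nM and 260000 nM.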

Compound 4, half-maximal inhibitory concentration: > 131000 nM
Compound 4: no number, only a limit; the forecaster's own chance of this, stated with the estimate: 75%; at least 1.0-fold (0.00 log units) between middle value and limit.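

In this assay, compound 2 and compound 4 each give only a limit of the assay, not a number. The step between them, tert-butyl in place of 4-fluorophenyl on an aromatic nitrogen, therefore cannot be read. The compounds shown leave open how large the effect of this change is, and what actual values compound 2, compound 3 and compound 4 would give.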